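Methoxy to ethyl on a core that barely inhibits

A few compounds are considered here, and "the series" means these few. Any claim that something is new, unique, unknown or untested is made for them only; others in the source may bear on it.

Compound 1 `COCc1nc(C)c2cnnc(S)n12`: in a functional assay for inhibition, with Homo sapiens as the target (a lower number here means a stronger inhibitor, a higher number a weaker inhibitor), compound 1 gives > 48000 nM, which is a limit of the assay rather than a number.
Compound 2 `COCc1ncc2cnnc(S)n12`: compound 2 gives > 48000 nM, again only a limit.
Compound 3 `CCCc1ncc2cnnc(SC)n12`: compound 3 gives > 48000 nM, also only a limit.

Compound 1 therefore stands at the limit, and so do the other two; (the limit of > 48000 nM in this assay, at which 3 of the 3 values shown sit). Going by the values given here, the only measured step, a step that the two limits leave unreadable from compound 1 to compound 2, cannot be read because both ends are limits.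

Compound 4 `CCCc1nc(C)c2cnnc(S)n12` differs from compound 1 by ethyl in place of methoxy on a saturated chain carbon bound to an aromatic carbon. Among the compounds with values here, no measured step bears on this change, and nothing among the three compounds points to a gain in potency.

Compound 4 is therefore expected to sit at the limit as well, with an estimate of 100000 nM and a range from 30000 nM to 500000 nM. The expected step that the limit leaves unreadable from compound 1 to compound 4 is none beyond the scatter.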

Compound 4, half-maximal inhibitory concentration: 10000 nM
The estimate for compound 4 lay 10-fold (1.00 log units) above the measured number; the whole stated range lies above it.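

In this assay, ethyl in place of methoxy on a saturated chain carbon bound to an aromatic carbon gives an at least 4.8-fold lower number from compound 1 to compound 4 (0.68 log units; beyond the scatter). So this position responds to change, and a small swap, methoxymethyl to propyl, is enough to bring the shared core within the measurable range. Compound 4 is the only compound shown with a true number, while the others remain at a limit: the limit of > 48000 nM in this assay, at which 3 of the 4 values shown sit.

As far as these compounds go, how far the number would move with a longer chain such as butyl, or with an amine at this place, remains open. From the compounds shown here alone, the exact size of the step also remains open, as only a limit is available for compound 1.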